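A few compounds are considered here, and "the series" means these few. Any claim that something is new, unique, unknown or untested is made for them only; others in the source may bear on it.

Compound 1 `Fc1ccc(-c2n[nH]cc2N2CCCNCC2)cc1`: 2290 nM
Compound 2 `COc1ccccc1-c1n[nH]cc1N1CCCNCC1`: > 10000 nM
Compound 3 `COc1ccccc1-c1n[nH]cc1N1CCNCC1`: > 10000 nM

In an assay on isolated protein for binding affinity to 5-hydroxytryptamine receptor 6 (Homo sapiens) (on this read-out higher numbers stand for weaker inhibition and lower numbers for stronger inhibition), compound 1 gives 2290 nM. For compound 2 the value > 10000 nM is a limit of the assay, not a number. For compound 3 the value > 10000 nM is likewise a limit, so compound 3 stands at the limit of > 10000 nM in this assay, at which 2 of the 3 values shown sit. Compound 4 `Fc1ccccc1-c1n[nH]cc1N1CCNCC1` has not yet been measured; it differs from compound 3 by fluoro in place of methoxy on an aromatic carbon. No step between measured compounds that differ in only one place is shown, so the size and direction of the change can only be expected. Since compound 1, which carries fluoro, gives in this assay a number, 2290 nM, compound 4 is expected to move toward stronger binding by an at least 2.0-fold lower number from compound 3 to compound 4 (0.30 log units; that floor lies within the scatter). For compound 4 the estimate is 5000 nM, within a range from 1500 nM to 20000 nM.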

Compound 4, inhibition constant: 713 nM
Compound 4: the middle estimate sits 7.0-fold (0.85 log units) above what was measured; the measured number lies below the stated range.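

At the aromatic carbon ortho to a large group, fluoro in place of methoxy gives the first single-place comparison: in this assay the swap gives an at least 14-fold lower number from compound 3 to compound 4 (1.14 log units; beyond the scatter) and shows that binding depends strongly on the group at this position. From the compounds shown here alone, the true size of the step stays unknown, since compound 3 has a limit rather than a number: the limit of > 10000 nM in this assay, at which 2 of the 4 values shown sit. A hydrogen, chlorine or methyl group at this carbon would help tell whether the gain belongs to fluoro or merely to losing methoxy. Going by these compounds, whether the same swap helps on the core of compound 2 also stays open.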